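Bromo to hydrogen on the amide aryl ring

A few compounds are considered here, and "the series" means these few. Any claim that something is new, unique, unknown or untested is made for them only; others in the source may bear on it.

Values in an assay on isolated protein for inhibition of thiosulfate sulfurtransferase (Homo sapiens), with a stated time of 60 min, in the absence of a further agent; on this read-out lower numbers stand for stronger inhibition and higher numbers for weaker inhibition:

compound 1, `COc1ccc(Br)cc1C(=O)Nc1ccc(Sc2nc3ccccc3s2)cc1`, gives > 100000 nM, a limit of the assay, not a number.
compound 2, `COc1c(Br)cc(Br)cc1C(=O)Nc1ccc(Sc2nc3ccccc3s2)cc1`, gives > 100000 nM, again a limit.
compound 3, `O=C(Nc1ccc(Sc2nc3ccccc3s2)c(Cl)c1)c1cc(Br)ccc1O`, gives > 100000 nM, also a limit.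

All three measured compounds sit at the limit of > 100000 nM in this assay, at which 3 of the 3 values shown sit, so no number separates them. The change from compound 2 to compound 1 is hydrogen in place of bromo on an aromatic carbon; its effect is a step that the two limits leave unreadable from compound 2 to compound 1. How the core of compound 3 differs from that of compound 2 is not broken down here.

Compound 4, `O=C(Nc1ccc(Sc2nc3ccccc3s2)c(Cl)c1)c1ccccc1O`, is to be measured in this assay. It differs from compound 3 by hydrogen in place of bromo on an aromatic carbon. This is the same kind of change as from compound 2 to compound 1, not the same: there the site is ortho to a methoxy group and meta to a bromo group, here it is para to a hydroxy group, while both are meta to a large group.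

Because compound 3 gives only > 100000 nM, a step that the limit leaves unreadable from compound 3 to compound 4 is expected, with a limit the likely outcome. The estimate for compound 4 is 200000 nM, between 50000 nM and 1000000 nM.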

Compound 4, half-maximal inhibitory concentration: > 100000 nM
Compound 4: no number, only a limit; the forecaster's own chance of this, stated with the estimate: 85%; the middle value is on the limit's open side.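

In this assay compound 4 gives > 100000 nM, a limit and not a number. Compound 3 gives > 100000 nM, also a limit, so the change from compound 3 to compound 4 yields no readable step. The compounds shown leave open what bromo to hydrogen does on this read-out, and which structure would give a number at all: the limit of > 100000 nM in this assay, at which 4 of the 4 values shown sit.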